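A few compounds are considered here, and "the series" means these few. Any claim that something is new, unique, unknown or untested is made for them only; others in the source may bear on it.

Compound 2 `CC(=O)c1cc(/C=C/c2ccc(F)cc2)cc2cc(-c3ccc(F)cc3)[nH]c12` gives 20.3% in a functional assay on HeLa cells (Homo sapiens) for cytotoxicity, read by MTT assay, with a stated time of 2 days, tested at 100 uM (on this read-out lower numbers stand for a stronger effect and higher numbers for a weaker effect at the one concentration tested), the lowest of the two numbers at hand. Compound 1 `COc1ccc(-c2cc3cc(-c4ccccc4)cc(C(C)=O)c3[nH]2)cc1` gives 32.8% in this assay, a number higher than that of compound 2 by more than the usual scatter. Compound 3 `COc1ccc(-c2cc3cc(/C=C/c4ccc(F)cc4)cc(C(C)=O)c3[nH]2)cc1` has not yet been measured; it differs from compound 2 by methoxy in place of fluoro on an aromatic carbon. For the measured compounds named here, no pair of measured compounds shows this change on its own, so the expected step of a number 6.7 percentage points higher from compound 2 to compound 3 (within the scatter) is a modest rise of the number, possibly no larger than the scatter. Compound 3 is therefore expected to give about 27%, between 13% and 42%.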

Compound 3, a percentage reported as activity, at one concentration (the size of the read-out at that concentration, not a potency): 18.9%
For compound 3 the middle estimate is 8.1 percentage points above the measured one, and the stated range covers the measured number.
By their numbers in this assay, from the lowest: compounds 3 and 2 (each within the scatter of the next); then compound 1.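

In this assay, methoxy in place of fluoro on this aromatic ring gives a number 1.4 percentage points lower from compound 2 to compound 3 (within the scatter), so the two groups cannot be told apart here. The other change, 2-(4-fluorophenyl)ethenyl in place of phenyl on an aromatic carbon, gives a number 13.9 percentage points lower from compound 1 to compound 3 (beyond the scatter), a step that stands out from the scatter. No measurement at hand explains either result. As far as these compounds go, whether an amine or a carboxylic acid in place of the methoxy would move the number remains open. Also open, from the compounds shown here alone, is whether a longer chain in place of the 2-(4-fluorophenyl)ethenyl group would do the same.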